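The compounds below may be only part of what the source reports. "The series", "measured", "known", "first", "only" and "open" are said of these compounds alone.

Of the compounds shown here, three have been measured in an assay on NIH3T3 cells with Urotensin-2 receptor (Homo sapiens) as the target; on this read-out lower numbers stand for an effect already at smaller amounts and higher numbers for an effect only at larger amounts of compound. Compound 1, `CN(C)CCC(OC(=O)c1ccc(-c2ccccc2)cc1)c1ccc(Cl)cc1`, gives 525 nM. Compound 2, `Cc1cc(Br)ccc1C(=O)OC(CCN(C)C)c1ccc(Cl)cc1`, gives 1070 nM. Compound 3, `CN(C)CCC(NC(=O)c1ccc(C(F)(F)F)cc1)c1ccc(Cl)cc1`, gives 77.6 nM, the lowest of the three numbers; its gap to compound 1 and its larger gap to compound 2 both lie beyond the usual scatter of repeated measurements. Going by the values given here, compound 3 is also the only one of the three that carries an amide rather than an ester, and the only one with a trifluoromethyl group.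

Compound 4, `CN(C)CCC(NC(=O)c1ccccc1)c1ccc(Cl)cc1`, has not yet been measured. It differs from compound 3 in one place: hydrogen in place of trifluoromethyl on an aromatic carbon. After the change the six-membered aromatic ring of carbon only at that end carries no substituent at all. Nothing measured here shows directly what such a removal does, since compound 1 and compound 2 are esters and each keeps a group on the corresponding ring, so they give no clean comparison. A loss of potency is expected, though its size is uncertain, and the step is estimated at a 5.2-fold higher number from compound 3 to compound 4 (0.71 log units; beyond the scatter). Compound 4 is expected to give about 400 nM in this assay, with a likely range from 100 nM to 1600 nM.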

Compound 4, half-maximal effective concentration: 1410 nM
Compound 4: middle estimate off by 3.5-fold (0.55 log units), on the low side, within the range that was stated.
By their numbers in this assay, from the lowest: compound 3; then compound 1; then compounds 2 and 4 (each within the scatter of the next).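

Hydrogen in place of trifluoromethyl on this aromatic carbon has a large effect in this assay: an 18-fold higher number from compound 3 to compound 4 (1.26 log units; beyond the scatter). Going by these compounds alone, this is the first pair that differs in one place only, so the size of a single change can now be read directly, and this carbon, para to a large group, proves to be far from a neutral spot. The amide with nothing on that carbon does not keep the low number of compound 3, at 77.6 nM, so within this pair the trifluoromethyl group is needed for that value, although nothing measured here explains why.

The compounds shown leave open whether trifluoromethyl itself matters or whether another group on that same carbon, such as a chlorine atom, a methyl group, a methoxy group or a nitrile, would serve as well. They also leave open what the amide contributes, since that would take an ester that carries trifluoromethyl on the same ring and is otherwise identical to compound 3.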